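The compounds below may be only part of what the source reports. "The series", "measured", "known", "first", "only" and "open" are said of these compounds alone.

Measured compounds:
Compound 1 `CC(=O)/C=C/C1CCCCC1`, which in a functional assay on A2780 cells (Homo sapiens) for antiproliferative activity, read by sulforhodamine B assay, with a stated time of 48 h (on this read-out lower numbers stand for stronger inhibition of growth and higher numbers for weaker inhibition of growth), gives 21000 nM.
Compound 2 `C/C(=C\CC(C)C)C(=O)c1ccccc1`, which in this assay gives only a limit, > 100000 nM.

Compound 2 therefore stands at the edge of what this assay can report: its value is a limit and not a number, and (the limit of > 100000 nM in this assay, at which 1 of the 2 values shown sits). Going by the values given here, compound 1 is the only measured compound with an actual number, and it sits well away from that limit.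

Compound 3 `CC(C)C/C=C(\CO)C(=O)c1ccccc1` is the next compound. It differs from compound 2 by hydroxy in place of hydrogen on a saturated chain carbon bound to a double-bonded chain carbon. Among the compounds with values here, no step between two measured compounds is available to gauge what this change does, so the expectation rests on little. The expected step is an at least 2.5-fold lower number from compound 2 to compound 3 (0.39 log units; beyond the scatter), a move toward stronger inhibition of growth that is small and uncertain, since the starting point is itself only a limit. Compound 3 is estimated at 40000 nM, within a range from 8000 nM to 200000 nM. A fair chance remains that this assay again reports only a limit for compound 3.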

Compound 3, concentration for 50% growth inhibition: 18000 nM
For compound 3 the middle estimate is 2.2-fold (0.35 log units) above the measured one, within the range that was stated.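

With hydroxy in place of hydrogen on a saturated chain carbon bound to a double-bonded chain carbon, compound 3 gives the actual number 18000 nM in this assay. Going by these compounds alone, this is the first reading of the change at this place, and it is an at least 5.5-fold lower number from compound 2 to compound 3 (0.74 log units; beyond the scatter) in the direction of stronger inhibition of growth. The step remains a bound and not a size because the value of compound 2 is only a limit: the limit of > 100000 nM in this assay, at which 1 of the 3 values shown sits.

The compounds shown leave open whether the gain belongs to hydroxy itself or would also appear with another group at this place, such as a methoxy, an amine or a carboxylic acid. They also leave open how a longer chain carrying the hydroxy would read out.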